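A Second Methoxy Group on Compound 2

The source may report more compounds than this note shows. Statements on the series, on what has been measured and on what is new or still open speak of the compounds shown alone.

Compound 1, `COc1ccc(/C=C/C(=O)NCCNc2ccnc3cc(Cl)ccc23)cc1OC`: 5600 nM
Compound 2, `COc1ccc(/C=C/C(=O)c2ccc(OCC(O)CNCCNc3ccnc4cc(Cl)ccc34)cc2)cc1`: 8030 nM

Both numbers come from an ADME assay on Vero cells (Chlorocebus sabaeus) for cytotoxicity, read by MTT assay, with a stated time of 72 h; a higher number here means that more compound is tolerated, a lower number that less compound is tolerated. Of the two, compound 2 carries the nominally higher one, but its gap to compound 1 lies within the scatter, so the two count as equal. Compound 3, `COc1ccc(/C=C/C(=O)c2ccc(OCC(O)CNCCNc3ccnc4cc(Cl)ccc34)cc2)cc1OC`, has not been measured. It differs from compound 2 by methoxy in place of hydrogen on an aromatic carbon. For the measured compounds named here, no measured pair shows this change on its own, so nothing fixes its size; in this assay the step is expected to stay within the scatter, in no clear direction. Compound 3 is therefore expected to give about 8000 nM, from 4000 nM to 16000 nM. That means an expected step of a 1.0-fold lower number from compound 2 to compound 3 (0.00 log units; within the scatter).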

Compound 3, half-maximal cytotoxic concentration: 10200 nM
The estimate for compound 3 lay 1.3-fold (0.11 log units) below the measured number; the range from low to high includes it.
By their numbers in this assay, from the lowest: compounds 1, 2 and 3 (each within the scatter of the next).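

Adding the second methoxy group, which turns 4-methoxyphenyl into 3,4-dimethoxyphenyl, gives in this assay a 1.3-fold higher number from compound 2 to compound 3 (0.10 log units; within the scatter), so compound 2 and compound 3 count as equal. For the compounds shown here, this is the first direct reading of the change, and at this position, ortho to a methoxy group, it produces no step that can be told from the scatter. Nothing available explains this result. Open, from the compounds shown here alone, is whether an ethoxy group or an amine at the same place would also stay within the scatter. Also open, going by these compounds, is whether the change reads alike on the shorter chain of compound 1.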